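Chain Lengthening in an Ester Series Tested for Cytotoxicity

This account rests on a few compounds, and the source may have more. Where it says the series, first, only, none or still open, it means among the compounds named here.

Measured so far:
compound 1 `CCCCCCOC(=O)CCC(=O)N1CCN(CCCOc2cc3c(Nc4ccc(F)c(Cl)c4)ncnc3cc2OC)CC1` gives 89.3% in a functional assay on A549 cells (Homo sapiens) for cytotoxicity, read by MTT assay, with a stated time of 24 h, tested at 10 uM; on this read-out higher numbers stand for a weaker effect at the one concentration tested and lower numbers for a stronger effect;
compound 2 `CCCCCCCOC(=O)CCC(=O)N1CCN(CCCOc2cc3c(Nc4ccc(F)c(Cl)c4)ncnc3cc2OC)CC1` gives 89.1%;
compound 3 `CCCCCCCCCCCCCCCCCOC(=O)CCC(=O)N1CCN(CCCOc2cc3c(Nc4ccc(F)c(Cl)c4)ncnc3cc2OC)CC1` gives 95.7%.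

All three share one core and differ only in the length of the ester chain. Compound 4 `CCCCCCCCCCCCCCCCCCOC(=O)CCC(=O)N1CCN(CCCOc2cc3c(Nc4ccc(F)c(Cl)c4)ncnc3cc2OC)CC1` extends this chain by one more carbon and has not yet been measured.

The change methyl in place of hydrogen on a saturated chain carbon, six bonds along the chain from an oxygen next to a carbonyl group made the step of a number 0.2 percentage points lower from compound 1 to compound 2 (within the scatter). From compound 3 to compound 4 the change is methyl in place of hydrogen on a saturated chain carbon, ten or more bonds along the chain from an oxygen next to a carbonyl group. Around the place the two differ, as the two descriptions of the entering group show: the carbon lies at a different distance along the chain from an oxygen next to a carbonyl group. So it is the same kind of change, not the same one. The two cores differ by undecyl in place of hydrogen on a saturated chain carbon, six bonds along the chain from an oxygen next to a carbonyl group, with the step of a number 6.4 percentage points higher from compound 1 to compound 3 (within the scatter), and compound 2 to compound 3 gave a number 6.6 percentage points higher from compound 2 to compound 3 (within the scatter).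

Since every step in this series lay within the scatter, the expected step for compound 4 is a number 0.7 percentage points lower from compound 3 to compound 4 (within the scatter). Compound 4 is estimated at 95%, between 87% and 100%.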

Compound 4, a percentage reported as activity, at one concentration (the size of the read-out at that concentration, not a potency): 94.8%
Compound 4: middle estimate off by 0.2 percentage points, on the high side, and the stated range covers the measured number.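

In this assay, methyl on the long chain gave a number 0.9 percentage points lower from compound 3 to compound 4 (within the scatter), and the same kind of change on the shorter chain gave a matching result: the same change on two cores in this assay, a number 0.2 percentage points lower (within the scatter) from compound 1 to compound 2 and a number 0.9 percentage points lower (within the scatter) from compound 3 to compound 4, 0.7 percentage points apart, within the scatter of two such steps

Undecyl, a far larger addition, gave a number 5.7 percentage points higher from compound 2 to compound 4 (within the scatter), and this too agrees with the same change on another core: the same change on two cores in this assay, a number 6.4 percentage points higher (within the scatter) from compound 1 to compound 3 and a number 5.7 percentage points higher (within the scatter) from compound 2 to compound 4, 0.7 percentage points apart, within the scatter of two such steps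

Dodecyl gave a number 5.5 percentage points higher from compound 1 to compound 4 (within the scatter), so all the steps here lie within the scatter, which shows only that these chain changes carried from one core to another without any step rising above the usual noise; it does not show that chain length affects this read-out, or that a change with a step beyond the scatter would carry over in the same way.

The compounds shown leave open whether a much shorter ester, such as a methyl or ethyl ester, or an amine or a carboxylic acid in place of the ester chain, would give a step beyond the scatter. They also leave open how this series would read at any other concentration.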